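Swapping (isopropylcarbonyl)oxy for trichloromethyl on compound 1

This account rests on a few compounds, and the source may have more. Where it says the series, first, only, none or still open, it means among the compounds named here.

In a physicochemical assay, read by HPLC, in phosphate buffer, with a stated time of 2 h, at pH 7.4 (on this read-out higher numbers stand for a more stable compound and lower numbers for a less stable compound), compound 1 (`CC(C)C(=O)OCOC(=O)N1CCN(C(=O)c2nc(Nc3cc(C4CC4)[nH]n3)c3cc(Cl)ccc3n2)C[C@H]1C`) gives 93.5%. Compound 2 (`COC(=O)N1CCN(C(=O)c2nc(Nc3cc(C4CC4)[nH]n3)c3cc(Cl)ccc3n2)C[C@H]1C`) gives 100%, and compound 3 (`CC(OC(=O)C(C)C)OC(=O)N1CCN(C(=O)c2nc(Nc3cc(C4CC4)[nH]n3)c3cc(Cl)ccc3n2)C[C@H]1C`) gives 96.6%. Compound 1 thus lies within the scatter of both others, and the three cannot be ranked.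

Compound 4 (`C[C@@H]1CN(C(=O)c2nc(Nc3cc(C4CC4)[nH]n3)c3cc(Cl)ccc3n2)CCN1C(=O)OCC(Cl)(Cl)Cl`) carries trichloromethyl in place of (isopropylcarbonyl)oxy on a saturated chain carbon bound to an oxygen next to a carbonyl group. Cut one bond further out, the same difference reads ((isopropylcarbonyl)oxy)methoxy to 2,2,2-trichloroethoxy.

The closest measured step removes the same (isopropylcarbonyl)oxy from the same place, with hydrogen entering: a number 6.5 percentage points higher from compound 1 to compound 2 (within the scatter). Methyl in place of hydrogen on the saturated chain carbon bound to two oxygens gives a number 3.1 percentage points higher from compound 1 to compound 3 (within the scatter). Exchanging methyl for 1-((isopropylcarbonyl)oxy)ethyl on an oxygen next to a carbonyl group gives a number 3.4 percentage points lower from compound 2 to compound 3 (within the scatter). Going by the values given here, no measured compound carries trichloromethyl, so the nearest guide is compound 2 at 100%, which also lacks (isopropylcarbonyl)oxy. No change beyond the scatter is therefore expected. The expected change in this assay is a number 3.5 percentage points higher from compound 1 to compound 4 (within the scatter). Compound 4 is estimated at 97%, with an expected range from 89% to 100%.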

Compound 4, percent of the compound remaining: 98.7%
The estimate for compound 4 lay 1.7 percentage points below the measured number, and the stated range covers the measured number.
By their numbers in this assay, from the lowest: compounds 1, 3, 4 and 2 (each within the scatter of the next).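

In this assay, trichloromethyl on a saturated chain carbon bound to an oxygen next to a carbonyl group gives a number 5.2 percentage points higher from compound 1 to compound 4 (within the scatter), so replacing (isopropylcarbonyl)oxy with a group of carbon and chlorine, which has no hydrogen-bond acceptors, produces no change that can be told from the scatter. The same holds against the other two compounds: 2,2,2-trichloroethyl in place of 1-((isopropylcarbonyl)oxy)ethyl gives a number 2.1 percentage points higher from compound 3 to compound 4 (within the scatter), and trichloromethyl in place of hydrogen gives a number 1.3 percentage points lower from compound 2 to compound 4 (within the scatter), so this place has now carried hydrogen, (isopropylcarbonyl)oxy and trichloromethyl with no step beyond the scatter. No measurement offers an explanation for this result.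

On these data alone, what remains open is whether an amine, a carboxylic acid or a longer chain at this place would give a step beyond the scatter in this assay. The compounds shown also leave open whether these four would stay within the scatter of one another over a longer time in the same buffer.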